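The compounds below may be only part of what the source reports. "The series", "measured", "known", "first", "only" and "open" are said of these compounds alone.

Compound 1 `CCc1ccccc1NS(=O)(=O)c1ccc(NC(=O)NCCCCl)cc1`; compound 2 `CCCc1ccccc1NS(=O)(=O)c1ccc(NC(=O)NCCCCl)cc1`; compound 3 `CCNC(=O)Nc1ccc(S(=O)(=O)Oc2ccccc2C)cc1`; compound 4 `CCNC(=O)Nc1ccc(S(=O)(=O)Oc2ccccc2CC)cc1`, not yet measured.

In a functional assay on M21 cells (Homo sapiens) for cytotoxicity, read by sulforhodamine B assay, with a stated time of 48 h (on this read-out lower numbers stand for stronger inhibition and higher numbers for weaker inhibition), compound 1 reaches only a limit, > 200000 nM. In this assay compound 2 gives 38000 nM. In this assay compound 3 gives 3100 nM, the lowest of the two numbers, with compound 2 nearest. The change methyl in place of hydrogen on a saturated chain carbon, two bonds along the chain from an aromatic carbon made an at least 5.2-fold lower number from compound 1 to compound 2 (0.72 log units; beyond the scatter); since that step starts from the limit of > 200000 nM in this assay, at which 1 of the 3 values shown sits, for compound 1, only a bound on its size is known. Compound 4 carries the same kind of change from compound 3, (methyl in place of hydrogen on a saturated chain carbon bound to an aromatic carbon), though here on a saturated chain carbon bound to an aromatic carbon rather than two bonds along the chain from an aromatic carbon. The difference between the two cores is not broken down here. For compound 4 in this assay a step of a 2.1-fold lower number from compound 3 to compound 4 (0.32 log units; beyond the scatter) is expected, smaller than the earlier one because an at least 5.2-fold lower number from compound 1 to compound 2 (0.72 log units; beyond the scatter) is a bound on a different core. Compound 4 is estimated at 1500 nM, between 400 nM and 5000 nM.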

Compound 4, half-maximal inhibitory concentration: 2500 nM
Estimate against measurement, compound 4: 1.7-fold (0.22 log units) below, within the range that was stated.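

In this assay methyl in place of hydrogen on a saturated chain carbon bound to an aromatic carbon gives no readable change on the core of compound 3 (a 1.2-fold lower number from compound 3 to compound 4 (0.09 log units; within the scatter)). The size of this change does not carry from one core to the other: the same change on two cores in this assay, an at least 5.2-fold lower number (0.72 log units; beyond the scatter) from compound 1 to compound 2 and a 1.2-fold lower number (0.09 log units; within the scatter) from compound 3 to compound 4, at least 4.2-fold (0.62 log units) apart, beyond the scatter of two such steps
Compound 1 stands at a limit and the earlier step is only a bound, and the reason for the gap between the two cores remains unknown: the limit of > 200000 nM in this assay, at which 1 of the 4 values shown sits.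

Still open, on these data alone, is whether a butyl chain in place of the ethyl group of compound 4 would stay as flat on this core. Also open, as far as these compounds go, is what an amine or a carboxylic acid at the end of that chain would do.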